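A few compounds are considered here, and "the series" means these few. Any claim that something is new, unique, unknown or untested is made for them only; others in the source may bear on it.

Measured in a functional assay on K562 cells (Homo sapiens) for antiproliferative activity, read by MTT assay; a higher number here means a weaker inhibitor, a lower number a stronger inhibitor:
- compound 1 `O=C1NC(c2ccccc2)CN1S(=O)(=O)c1ccc2c(c1)CCCN2`: > 20000 nM, a limit
- compound 2 `CCCOC(=O)N1CCCc2cc(S(=O)(=O)N3CC(c4ccccc4)NC3=O)ccc21`: > 20000 nM, a limit
- compound 3 `CCCCOC(=O)N1CCCc2cc(S(=O)(=O)N3CC(c4ccccc4)NC3=O)ccc21`: 3680 nM

Compound 3 alone carries a number. The other two compounds stand at the limit of > 20000 nM in this assay, at which 2 of the 3 values shown sit.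

Compound 4 `C=CCOC(=O)N1CCCc2cc(S(=O)(=O)N3CC(c4ccccc4)NC3=O)ccc21` differs from compound 3 as follows: vinyl in place of propyl on a saturated chain carbon bound to an oxygen next to a carbonyl group. Read one bond further out, butoxycarbonyl becomes allyloxycarbonyl. Among the compounds with values here, two measured steps bear on this: an at least 5.4-fold lower number from compound 2 to compound 3 (0.73 log units; beyond the scatter), where methyl replaces hydrogen on the saturated chain, and an at least 5.4-fold lower number from compound 1 to compound 3 (0.73 log units; beyond the scatter), where butoxycarbonyl replaces hydrogen. The step from compound 1 to compound 2 cannot be read, as both ends are limits. Since the butoxycarbonyl group is lost, a move back towards weaker inhibition in this assay is expected, estimated as a 3.8-fold higher number from compound 3 to compound 4 (0.58 log units; beyond the scatter). For compound 4 the estimated value is 14000 nM, with an expected range of 5000 nM to 30000 nM.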

Compound 4, half-maximal inhibitory concentration: 473 nM
Compound 4: middle estimate off by 30-fold (1.47 log units), on the high side, and the stated range ends above it.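

In this assay, butoxycarbonyl is not the best group shown at this position: allyloxycarbonyl gives a 7.8-fold lower number from compound 3 to compound 4 (0.89 log units; beyond the scatter). A longer chain therefore does not simply mean a lower number, and compound 4 goes against that reading. With vinyl in place of ethyl the result is an at least 42-fold lower number from compound 2 to compound 4 (1.62 log units; beyond the scatter), and with allyloxycarbonyl in place of hydrogen it is an at least 42-fold lower number from compound 1 to compound 4 (1.62 log units; beyond the scatter), both bounds only: the limit of > 20000 nM in this assay, at which 2 of the 4 values shown sit.

On these data alone, whether a longer unsaturated chain, or a benzyloxycarbonyl group, lowers the number further remains open. So does the reading of a propargyloxycarbonyl group at this position.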